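Adding an Octyloxy Chain to a Bis-Pyrazole Scaffold

A few compounds are considered here, and "the series" means these few. Any claim that something is new, unique, unknown or untested is made for them only; others in the source may bear on it.

Of the compounds shown here, two have been tested in a functional assay on Bel-7402 cells (Homo sapiens) for cytotoxicity, read by MTT assay, with a stated time of 48 h; on this read-out higher numbers stand for weaker inhibition and lower numbers for stronger inhibition. Compound 1 `O=[N+]([O-])c1ccc(-n2cc(-c3ccncc3)cn2)cc1` gives 23200 nM in this assay. Compound 2 `Cc1nn(-c2ccc([N+](=O)[O-])cc2)c(C)c1-c1cccc(-c2c(C)nn(-c3ccc([N+](=O)[O-])cc3)c2C)c1` gives 11800 nM in this assay. The two numbers sit close enough to each other that the usual spread of repeated measurements covers the gap, so neither compound can be said to inhibit more strongly than the other on this evidence.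

Compound 3 `CCCCCCCCOc1cc(-c2c(C)nn(-c3ccc([N+](=O)[O-])cc3)c2C)cc(-c2c(C)nn(-c3ccc([N+](=O)[O-])cc3)c2C)c1` has not yet been measured. It carries the same two nitrophenyl-pyrazole arms as compound 2 on the shared central ring, and differs in one place: octyloxy in place of hydrogen on an aromatic carbon.

Among the compounds with values here, no pair of measured compounds differing in a single group is available, so there is no directly comparable step to lean on. With only two measured points that cannot be told apart, the expectation for compound 3 is a small step, estimated as a 1.5-fold lower number from compound 2 to compound 3 (0.17 log units; within the scatter), leaning toward stronger inhibition but not clearly beyond the scatter. Compound 3 is therefore expected to give about 8000 nM in this assay, within a range from 2500 nM to 30000 nM.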

Compound 3, half-maximal inhibitory concentration: 5220 nM
Beside the measured number, compound 3's estimate is 1.5-fold (0.19 log units) above it, and the stated range covers the measured number.
By their numbers in this assay, from the lowest: compound 3; then compounds 2 and 1 (each within the scatter of the next).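

In this assay, this series now has its first comparison of two compounds that differ in a single place: putting octyloxy in place of hydrogen on an aromatic carbon, meta to two large groups, gives a 2.3-fold lower number from compound 2 to compound 3 (0.35 log units; beyond the scatter). Until now, the two measured compounds could not be told apart, whereas this step lies beyond the usual scatter, although it is modest. It shows that this carbon can carry a chain of this size without any loss of inhibition, and with a small gain, but nothing measured here accounts for the change.

One step with one group cannot show what part of the octyloxy group matters: a plain octyl chain without the oxygen would separate the chain from the oxygen, while methoxy, butoxy or a longer chain such as dodecyloxy would show whether the number keeps falling as the chain grows. A hydroxyl group, an amine or a carboxylic acid on the same carbon remains an open question too, as does whether octyloxy would have a similar effect on this scaffold in other cell lines.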